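Notes on the step from cyclobutyl to pyridin-3-yl

This account rests on a few compounds, and the source may have more. Where it says the series, first, only, none or still open, it means among the compounds named here.

Measured compounds:
Compound 1 (`O=C(NC1CCCC1)[C@@H]1CN(c2ccc(C(F)(F)F)cc2)CC(=O)N1c1ccc2ccsc2c1`) | 20000 nM
Compound 2 (`O=C(NC1CCC1)C1CN(c2ccccc2)CC(=O)N1c1ccc2ccsc2c1`) | > 50000 nM

Both values come from an ADME assay on HepG2 cells (Homo sapiens) for cytotoxicity (a lower number here means that less compound is tolerated, a higher number that more compound is tolerated), and give the half-maximal cytotoxic concentration. Compound 2 stands at > 50000 nM in this series, and this is a limit of the assay, not a number. Among the measured compounds shown here, compound 1 gives the only actual number so far (20000 nM), but it differs from compound 2 in more than one place, so no single change can be read from the pair.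

Compound 3 (`O=C(Nc1cccnc1)C1CN(c2ccccc2)CC(=O)N1c1ccc2ccsc2c1`) has pyridin-3-yl in place of cyclobutyl on an amide-type nitrogen. For the measured compounds named here, no measured step covers this exchange. The expectation therefore rests on compound 1 (20000 nM), which shows that a number can be reached on a closely related structure. A small downward step is expected in this assay, and it may not go beyond the scatter (an at least 1.2-fold lower number from compound 2 to compound 3 (0.09 log units; that floor lies within the scatter)). Compound 3 is estimated at 40000 nM with an expected range from 15000 nM to 50000 nM in this assay, and a limit rather than a number is also expected to be a likely outcome.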

Compound 3, half-maximal cytotoxic concentration: > 50000 nM
Compound 3: no number, only a limit; the forecaster's own chance of this, stated with the estimate: 55%; middle value at least 1.2-fold (0.09 log units) away from the limit.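

In this assay no step can be read from compound 2 to compound 3, because each of the two compounds gives only a limit of the assay and not a number: the limit of > 50000 nM in this assay, at which 2 of the 3 values shown sit. The compounds shown leave open how far, if at all, pyridin-3-yl in place of cyclobutyl on an amide-type nitrogen shifts the half-maximal cytotoxic concentration.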